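The compounds below may be only part of what the source reports. "The series", "measured", "known", "first", "only" and "open" are said of these compounds alone.

Measured compounds:
compound 1, `CC(=O)N1N=C(c2ccc(-n3c(C)ccc3C)cc2)OC1c1ccccc1Cl` — 206000 nM
compound 2, `Clc1ccc(-c2nnc(-c3ccc(-n4cccc4)cc3)o2)cc1` — 256000 nM
compound 3, `Cc1ccc(C)n1-c1ccc(C(=O)N/N=C/c2ccc(O)cc2)cc1` — "not determined" (no result reported)

In an ADME assay on A549 cells (Homo sapiens) for cytotoxicity, read by MTT assay, with a stated time of 72 h (on this read-out lower numbers stand for stronger inhibition and higher numbers for weaker inhibition), compound 1 gives 206000 nM. Of the two compounds with a number, compound 1 has the lower one; the nearest neighbour is compound 2, whose 256000 nM lies within the scatter of repeated measurements, so the two cannot be told apart on these data. For compound 3 no result was reported in this assay, so nothing can be said of where it stands.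

The step of interest runs from compound 1 to compound 4, `CC(=O)N1N=C(c2ccc(-n3c(C)ccc3C)cc2)OC1c1ccccc1`. The change is hydrogen in place of chloro on an aromatic carbon. It sits on an aromatic carbon of a six-membered aromatic ring of carbon only, and the rest of the shared core is kept. Among the compounds with values here, no pair of measured compounds shows this change, so its size has to be guessed from the two numbers at hand, which are both weak and close together.

Compound 4 is therefore expected to stay in the same weak region, with a step of a 1.2-fold higher number from compound 1 to compound 4 (0.08 log units; within the scatter) that is estimated to be no larger than the scatter and, if anything, toward a slightly higher number. The estimate for compound 4 in this assay is 250000 nM, with a range from 120000 nM to 500000 nM.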

Compound 4, half-maximal inhibitory concentration: 198000 nM
The estimate for compound 4 lay 1.3-fold (0.10 log units) above the measured number, and the stated range covers the measured number.
By their numbers in this assay, from the lowest: compounds 4, 1 and 2 (each within the scatter of the next).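

In this assay, the exchange of 2-chlorophenyl for phenyl gives a 1.0-fold lower number from compound 1 to compound 4 (0.02 log units; within the scatter), which lies within the scatter, so the two compounds cannot be told apart in this assay. Within the data shown here, this is the first pair that differs in one place, and it gives a direct reading that was previously available only as a guess: on this aromatic carbon, ortho to a large group, chloro and hydrogen give numbers that are indistinguishable, and the chloro is not needed to keep the number where it stands on this core. Nothing available bears on why the two compounds read alike, and one pair gives no basis for a wider rule about this position.

The compounds shown leave open whether any other group on this aromatic carbon, such as an amine, a carboxylic acid or a longer chain, would move the number beyond the scatter in either direction. They also leave open whether the exchange of chloro for hydrogen would read the same way on a different core.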